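This account rests on a few compounds, and the source may have more. Where it says the series, first, only, none or still open, it means among the compounds named here.

The measured compounds and their values in a functional assay on A549 cells (Homo sapiens) for inhibition, read by colorimetric assay and MTT assay, with a stated time of 72 h; a lower number here means a stronger inhibitor, a higher number a weaker inhibitor:
compound 1, `COc1ccc(C(=O)NNC(=S)Nc2csc(-c3ccccc3)c2)cc1`, 36000 nM
compound 2, `COc1ccc(C(=O)NNC(=S)Nc2csc(-c3ccc(C)cc3)c2)cc1`, 11000 nM
compound 3, `COc1ccc(C(=O)NNC(=S)Nc2csc(-c3ccccc3)c2)cc1OC`, 20000 nM

Compound 2 differs from compound 1 by methyl in place of hydrogen on an aromatic carbon, and this change brought a 3.3-fold lower number from compound 1 to compound 2 (0.51 log units; beyond the scatter). Compound 3 differs from compound 1 by methoxy in place of hydrogen on an aromatic carbon, a change that brought a 1.8-fold lower number from compound 1 to compound 3 (0.26 log units; within the scatter), so the numbers of compound 1 and compound 3 cannot be told apart.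

Compound 4, `COc1ccc(C(=O)NNC(=S)Nc2csc(-c3ccc(C)cc3)c2)cc1OC`, has not yet been measured in this assay. It differs from compound 3 by methyl in place of hydrogen on an aromatic carbon. Among the compounds with values here, this is the same change as the one from compound 1 to compound 2, made on the core of compound 3 instead of the core of compound 1; the two cores differ by the change just described under compound 3. Because a 3.3-fold lower number from compound 1 to compound 2 (0.51 log units; beyond the scatter) was seen once, a step of similar size is expected here, the estimate being a 2.9-fold lower number from compound 3 to compound 4 (0.46 log units; beyond the scatter). The expectation rests on a single earlier step, so it is uncertain. Compound 4 is therefore expected to give about 7000 nM, between 3000 nM and 16000 nM.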

Compound 4, half-maximal inhibitory concentration: 36000 nM
Estimate against measurement, compound 4: 5.1-fold (0.71 log units) below; the whole stated range lies below it.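

In this assay, the methyl change did not carry over from one core to the other, giving a 1.8-fold higher number from compound 3 to compound 4 (0.26 log units; within the scatter) on the core of compound 3, and the two steps differ: the same change on two cores in this assay, a 3.3-fold lower number (0.51 log units; beyond the scatter) from compound 1 to compound 2 and a 1.8-fold higher number (0.26 log units; within the scatter) from compound 3 to compound 4, 5.9-fold (0.77 log units) apart, beyond the scatter of two such steps. The methoxy change depended on the core in the same way, giving a 3.3-fold higher number from compound 2 to compound 4 (0.51 log units; beyond the scatter) on the core of compound 2: the same change on two cores in this assay, a 1.8-fold lower number (0.26 log units; within the scatter) from compound 1 to compound 3 and a 3.3-fold higher number (0.51 log units; beyond the scatter) from compound 2 to compound 4, 5.9-fold (0.77 log units) apart, beyond the scatter of two such steps. The two changes therefore do not add up across these compounds, but this rests on a single set of four values, and it shows neither why they fail to add up nor whether the same would hold on any other core.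

The compounds shown leave open how a chlorine, an amine or a carboxylic acid in place of the methyl of the 4-methylphenyl group would read in this assay on either core. Also open, going by these compounds, is whether a longer chain in place of the added methoxy would depend on the core as the methoxy does.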